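Sulfonylpiperazine for Piperidine on a Longer Chain

This account rests on a few compounds, and the source may have more. Where it says the series, first, only, none or still open, it means among the compounds named here.

Compound 1 `COc1cc(N)c(Cl)cc1C(=O)NC1CCN(CCN2CCCCC2)CC1` carries a piperidine on a short chain. In a functional assay on HEK293 cells for activation of 5-hydroxytryptamine receptor 4 (Homo sapiens), read by cAMP accumulation (a higher number here means a larger maximal response, a lower number a smaller maximal response), compound 1 reaches > 100%, which is a limit of the assay rather than a number. Compound 2 `COc1cc(N)c(Cl)cc1C(=O)NC1CCN(CCCCCCCCN2CCCCC2)CC1` has a longer chain; how its core differs from that of compound 1 is not broken down here. In this assay compound 2 reaches > 100%, again a limit and not a number. Compound 3 `COc1cc(N)c(Cl)cc1C(=O)NC1CCN(CCN2CCN(S(C)(=O)=O)CC2)CC1` differs from compound 1 by 4-(methylsulfonyl)piperazin-1-yl in place of piperidin-1-yl on a saturated chain carbon, two bonds along the chain from an amine nitrogen in a ring. In this assay compound 3 gives 97%, so the step of a number at least 3 percentage points lower from compound 1 to compound 3 (that floor lies within the scatter) is small. Compound 4 `COc1cc(N)c(Cl)cc1C(=O)NC1CCN(CCCCCCCCN2CCN(S(C)(=O)=O)CC2)CC1` differs from compound 2 by 4-(methylsulfonyl)piperazin-1-yl in place of piperidin-1-yl on a saturated chain carbon, eight bonds along the chain from an amine nitrogen in a ring; the place lines differ, two bonds against eight bonds along the chain, so this is the same kind of change, not the same change. Because (the limit of > 100% in this assay, at which 2 of the 3 values shown sit), a step from compound 2 can only be read against a limit. For compound 4 a step of a number at least 4 percentage points lower from compound 2 to compound 4 (that floor lies within the scatter) is expected in this assay, resting on the small step of a number at least 3 percentage points lower from compound 1 to compound 3 (that floor lies within the scatter). Compound 4 is therefore estimated at 96%, between 82% and 108%.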

Compound 4, intrinsic activity: the largest response reached, in percent of the reference agonist's: > 100%
Compound 4: only a limit was reported (the forecaster's own chance of this, stated with the estimate: 30%); middle value at least 4 percentage points away from the limit.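

No step can be read from compound 2 to compound 4, because each of the two compounds gives only a limit of the assay and not a number: the limit of > 100% in this assay, at which 3 of the 4 values shown sit.
The compounds shown leave open how large the maximal responses of compound 2 and compound 4 really are, and so whether 4-(methylsulfonyl)piperazin-1-yl in place of piperidin-1-yl changes the response on the longer chain at all.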